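Adding a Second Bromo: From Compound 2 to Compound 4

The compounds below may be only part of what the source reports. "The series", "measured", "known", "first", "only" and "open" are said of these compounds alone.

Measured so far in a functional assay on A549 cells (Homo sapiens) for inhibition, read by MTT assay, with a stated time of 48 h; on this read-out higher numbers stand for weaker inhibition and lower numbers for stronger inhibition:
compound 1, `COc1cc(/C=N/Nc2nc(-c3ccc(Br)cc3)cs2)cc(Br)c1OC`, gives 52300 nM
compound 2, `COc1cc(/C=N/Nc2nc(-c3cc(C(F)(F)F)cc(C(F)(F)F)c3)cs2)cc(Br)c1OC`, gives 94200 nM
compound 3, `COc1cc(/C=N/Nc2nc(-c3ccc(Br)cc3)cs2)c(Br)c(Br)c1OC`, gives 46100 nM

Compound 3 differs from compound 1 by bromo in place of hydrogen on an aromatic carbon, and that step is a 1.1-fold lower number from compound 1 to compound 3 (0.05 log units; within the scatter). Compound 4, `COc1cc(/C=N/Nc2nc(-c3cc(C(F)(F)F)cc(C(F)(F)F)c3)cs2)c(Br)c(Br)c1OC`, has not been measured; it differs from compound 2 by bromo in place of hydrogen on an aromatic carbon, the same change at the same place. How the core of compound 2 differs from the core of compound 1 is not broken down here, and the two values lie within the usual scatter of each other. The step from compound 2 to compound 4 is estimated as a 1.1-fold lower number from compound 2 to compound 4 (0.04 log units; within the scatter), resting on the change being the same because a 1.1-fold lower number from compound 1 to compound 3 (0.05 log units; within the scatter) stayed within the scatter. Compound 4 is therefore expected to give about 85000 nM in this assay, between 40000 nM and 180000 nM.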

Compound 4, half-maximal inhibitory concentration: > 100000 nM
Compound 4 ended at the assay's limit; the forecaster's own chance of this, stated with the estimate: 15%; middle value at least 1.1-fold (0.07 log units) from the limit.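

In this assay compound 4 gives > 100000 nM, which is a limit of the assay and not a number. Read against that limit, adding the bromo gives an at least 1.0-fold higher number from compound 2 to compound 4 (0.02 log units; that floor lies within the scatter), and the comparison with the earlier step stays unsettled: the same change on two cores in this assay, a 1.1-fold lower number (0.05 log units; within the scatter) from compound 1 to compound 3 and an at least 1.0-fold higher number (0.02 log units; that floor lies within the scatter) from compound 2 to compound 4; the limit leaves it open whether they differ The result neither proves that the change carries over from one core to the other nor shows that it fails to, and the limit hides the one value that could decide this: the limit of > 100000 nM in this assay, at which 1 of the 4 values shown sits.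

The compounds shown leave open whether a group other than bromo at this place, such as an amine or a carboxylic acid, would give a clearly different number. They also leave open how the bromo step would read on a further core whose values stay clear of the limit.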